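Extending an ethoxy chain to hexyloxy on a shared core

This account rests on a few compounds, and the source may have more. Where it says the series, first, only, none or still open, it means among the compounds named here.

Compound 1 `CCCCCCOc1ccc2c(Cl)ccnc2c1` gives 2380 nM in a functional assay on BGC-823 cells (Homo sapiens) for cytotoxicity, read by MTT assay, with a stated time of 48 h; a higher number here means a weaker inhibitor, a lower number a stronger inhibitor.
Compound 2 `CCOc1ccc2c(Cl)ccnc2c1` gives 3910 nM in this assay.
Compound 3 `CCOc1ccc2c(NCCN(C)C)ccnc2c1` gives 2520 nM in this assay.

Compound 1 differs from compound 2 by butyl in place of hydrogen on a saturated chain carbon, two bonds along the chain from an oxygen on an aromatic ring. That step gave a 1.6-fold lower number from compound 2 to compound 1 (0.22 log units; within the scatter). Compound 3 differs from compound 2 in another part of the molecule, by (2-(dimethylamino)ethyl)amino in place of chloro on an aromatic carbon, and that step gave a 1.6-fold lower number from compound 2 to compound 3 (0.19 log units; within the scatter). Compound 4 `CCCCCCOc1ccc2c(NCCN(C)C)ccnc2c1` has not yet been measured in this assay. It differs from compound 3 by butyl in place of hydrogen on a saturated chain carbon, two bonds along the chain from an oxygen on an aromatic ring, the same change that was made from compound 2 to compound 1, at the same place; the two cores on which it is made differ from each other by (2-(dimethylamino)ethyl)amino in place of chloro on an aromatic carbon.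

Going by the values given here, only one earlier example of this change exists here, and its step was within the scatter, so the expectation for compound 4 is loose. The step from compound 3 to compound 4 is expected to be about as large as the earlier one, a 1.6-fold lower number from compound 3 to compound 4 (0.20 log units; within the scatter), because compound 1 showed a 1.6-fold lower number from compound 2 to compound 1 (0.22 log units; within the scatter). Compound 4 is therefore estimated at 1600 nM in this assay, expected to fall between 700 nM and 3600 nM.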

Compound 4, half-maximal inhibitory concentration: 1090 nM
Compound 4: the middle estimate sits 1.5-fold (0.17 log units) above what was measured; the range from low to high includes it.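

In this assay, extending ethoxy to hexyloxy on the core carrying (2-(dimethylamino)ethyl)amino gave a 2.3-fold lower number from compound 3 to compound 4 (0.36 log units; beyond the scatter), and this agrees with the same extension on the chloro core: the same change on two cores in this assay, a 1.6-fold lower number (0.22 log units; within the scatter) from compound 2 to compound 1 and a 2.3-fold lower number (0.36 log units; beyond the scatter) from compound 3 to compound 4, 1.4-fold (0.15 log units) apart, within the scatter of two such steps. Placing (2-(dimethylamino)ethyl)amino in place of chloro on the hexyloxy core gave a 2.2-fold lower number from compound 1 to compound 4 (0.34 log units; beyond the scatter), and this also agrees with the same replacement on the ethoxy core: the same change on two cores in this assay, a 1.6-fold lower number (0.19 log units; within the scatter) from compound 2 to compound 3 and a 2.2-fold lower number (0.34 log units; beyond the scatter) from compound 1 to compound 4, 1.4-fold (0.15 log units) apart, within the scatter of two such steps. Each change therefore carried from one core to the other with no difference that stands out from the scatter, but each comparison rests on a single pair of steps, so this does not show that either change is really larger on one core or that it would carry to other cores.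

The compounds shown leave open how a chain of intermediate length, such as butoxy, or a longer chain than hexyloxy would behave on these cores. They also leave open whether another amine in place of chloro, such as a longer diamine chain, would combine with the hexyloxy chain in the same way.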